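The source may hold more compounds than are shown below. What is called first, only, known or untested is meant among the compounds shown, and "the series" means these compounds.

Measured so far:
- Compound 1, `COc1cc2ncnc(N3CCc4ccccc43)c2cc1NC(=O)/C=C/CN1CCCCC1`, gives 4180 nM in a functional assay on PC-3 cells (Homo sapiens) for antiproliferative activity, read by MTT assay, with a stated time of 72 h; on this read-out higher numbers stand for weaker inhibition and lower numbers for stronger inhibition.
- Compound 2, `CN(C)C/C=C/C(=O)Nc1cc2c(N3CCc4ccccc43)ncnc2cc1O[C@@H]1CCOC1`, gives 1230 nM in this assay.

Compound 2 has the lowest of the two numbers on hand; its nearest neighbour is compound 1, whose number is higher by a gap beyond the scatter. Among the compounds with values here, the two differ from each other in more than one spot, so the data contain no single step that isolates either change. Compound 3, `O=C(/C=C/CN1CCCCC1)Nc1cc2c(N3CCc4ccccc43)ncnc2cc1O[C@@H]1CCOC1`, is still to be measured in this assay. It differs from compound 2 by piperidin-1-yl in place of dimethylamino on a saturated chain carbon bound to a double-bonded chain carbon. Within the data shown here, with no measured step of this kind available, the expectation can rest only on the two values shown: compound 3 is expected to sit near compound 2, with at most a modest step upward, a 1.6-fold higher number from compound 2 to compound 3 (0.21 log units; within the scatter), since the shared change from compound 1 to compound 2 gave the lower number. Compound 3 is thus estimated at 2000 nM, within a range of 800 nM to 5000 nM.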

Compound 3, half-maximal inhibitory concentration: 4510 nM
The estimate for compound 3 lay 2.3-fold (0.35 log units) below the measured number; low and high end bracket the measured number.
By their numbers in this assay, from the lowest: compound 2; then compounds 1 and 3 (each within the scatter of the next).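

Compound 3 separates the two changes that were tied together in compounds 1 and 2. With oxolan-3-yl on the oxygen held fixed, piperidin-1-yl in place of dimethylamino on the saturated chain carbon gives a 3.7-fold higher number from compound 2 to compound 3 (0.56 log units; beyond the scatter) in this assay, a step beyond the scatter, whereas with piperidin-1-yl held fixed, oxolan-3-yl in place of methyl on the oxygen gives a 1.1-fold higher number from compound 1 to compound 3 (0.03 log units; within the scatter), which lies within the scatter. The data hold no measurement that accounts for the step at the chain carbon.

The compounds shown leave open whether the dimethylamino to piperidin-1-yl step keeps its size with methyl on the oxygen. They also do not show where other amines at this carbon, such as pyrrolidin-1-yl or morpholin-4-yl, would fall relative to these two groups.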